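The source may hold more compounds than are shown below. What is called first, only, known or untested is meant among the compounds shown, and "the series" means these compounds.

Measured so far:
- compound 1, `CC(C)(C)Nc1nc(N)c(C(=O)N=C(N)N)nc1Cl`: 48%
- compound 2, `NC(N)=NC(=O)c1nc(Cl)c(NCc2ccccc2F)nc1N`: 92%
- compound 3, `NC(N)=NC(=O)c1nc(Cl)c(OCc2ccc3ccccc3c2)nc1N`: "not determined" (no result reported)

Two compounds have numbers in an assay for inhibition of acid-sensing ion channel 3 (Homo sapiens), read by patch clamp, tested at 20 uM; on this read-out lower numbers stand for less inhibition and higher numbers for more inhibition at the one concentration tested (going by the name of the read-out). Compound 1 gives 48%, the lower of the two; compound 2 gives 92%, a value well beyond the scatter above it. Compound 3 carries an aromatic ring but no result is reported for it.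

Compound 4, `NC(N)=NC(=O)c1nc(Cl)c(Oc2ccccc2)nc1N`, is not yet measured. It differs from compound 1 in one place: phenoxy in place of (tert-butyl)amino on an aromatic carbon

Within the data shown here, since no step between measured compounds is recorded, the size of the change cannot be read from a measured pair. Compound 4 shares with compound 2 an aromatic ring at this position, and compound 2 gives 92%, so a step upward is expected, a number 27 percentage points higher from compound 1 to compound 4 (beyond the scatter), though its size is uncertain.

Compound 4 is expected to give about 75%, within 45% to 95%.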

Compound 4, a percentage reported as inhibition, at one concentration (the size of the read-out at that concentration, not a potency): 90%
For compound 4 the middle estimate is 15 percentage points below the measured one, within the range that was stated.
By their numbers in this assay, from the lowest: compound 1; then compounds 4 and 2 (each within the scatter of the next).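

In this assay, putting phenoxy in place of (tert-butyl)amino on this aromatic carbon gives a number 42 percentage points higher from compound 1 to compound 4 (beyond the scatter). Among these compounds, this is the first measured single change at this position, and it shows that the read-out responds strongly to the group placed there. It also shows that high inhibition does not need a hydrogen-bond donor on this group, since phenoxy has none. No available evidence explains the rise.

Still open, from the compounds shown here alone, is how a methoxy group or a cyclohexyloxy group, whose ring is not aromatic, would behave at this position.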